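The source may hold more compounds than are shown below. What is called first, only, known or untested is meant among the compounds shown, and "the series" means these compounds.

Compound 1, with the structure `CCO/N=C/c1c(N)ncnc1Oc1ccc2[nH]c(C)cc2c1F`, is the reference point here. In a functional assay on HCT-116 cells (Homo sapiens) for antiproliferative activity (a higher number here means a weaker inhibitor, a lower number a stronger inhibitor), compound 1 gives 36 nM, the lowest of the three numbers measured. Compound 2 `Cc1cc2c(F)c(Oc3ncnc(N)c3/C=N/OCCCO)ccc2[nH]1` gives 452 nM in this assay, and compound 3 `CO/N=C/c1c(N)ncnc1Oc1ccc2c(ccn2C)c1` gives 749 nM. For the measured compounds named here, the one single-change step among the measured compounds is a 13-fold higher number from compound 1 to compound 2 (1.10 log units; beyond the scatter), a large step.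

Compound 4 `Cc1cc2c(F)c(Oc3ncnc(N)c3/C=N/OCC3CCCCC3)ccc2[nH]1` also starts from compound 1, but changes a different part of the chain: cyclohexyl in place of methyl on a saturated chain carbon bound to an oxygen on an unsaturated carbon. Unlike the step from compound 1 to compound 2, which brought in a hydroxymethyl group with a hydrogen-bond donor and acceptor, this change adds only carbon, with no donors or acceptors, so that step bears on it only loosely. It does show that growing this chain can cost potency, so the expectation is a modest rise in the number, smaller than the step to compound 2. Compound 4 is therefore estimated at 110 nM, with a range from 30 nM to 400 nM, which would mean a 3.1-fold higher number from compound 1 to compound 4 (0.49 log units; beyond the scatter).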

Compound 4, half-maximal inhibitory concentration: 16100 nM
For compound 4 the middle estimate is 150-fold (2.17 log units) below the measured one, outside the stated range (above it).
By their numbers in this assay, from the lowest: compound 1; then compounds 2 and 3 (each within the scatter of the next); then compound 4.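

In this assay, putting cyclohexyl in place of methyl on this saturated chain carbon gives a 450-fold higher number from compound 1 to compound 4 (2.65 log units; beyond the scatter), so a change that adds only carbon, with no hydrogen-bond donors or acceptors, can cost far more here than the hydroxymethyl change did. Putting cyclohexyl in place of 2-hydroxyethyl still gives a 36-fold higher number from compound 2 to compound 4 (1.55 log units; beyond the scatter), so these two enlarged chains are far from equal at this position. Nothing measured here gives a reason for the size of this loss.

The compounds shown leave open whether a smaller group such as cyclopropyl or a straight propyl chain would keep the number close to that of compound 1, and so where the loss begins. They also leave open whether phenyl, or an amine on the cyclohexyl ring, would fare any better.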